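Amino in place of hydrogen on compound 2

The source may hold more compounds than are shown below. What is called first, only, known or untested is meant among the compounds shown, and "the series" means these compounds.

Of the compounds shown here, two have numbers so far. In a functional assay on HT-1080 cells (Homo sapiens) for antiproliferative activity, read by MTT assay, with a stated time of 72 h (on this read-out lower numbers stand for stronger inhibition and higher numbers for weaker inhibition), compound 2 `COc1ccc(-c2ssc(=O)c2-c2cc(OC)c(OC)c(OC)c2)cc1` gives 464 nM, the lower of the two values. Compound 1 `COc1ccc(-c2c(-c3cc(OC)c(OC)c(OC)c3)ssc2=S)cc1N` gives 3000 nM in this assay, and this gap lies beyond the scatter. Compound 2 is therefore the better of the pair on this read-out.

The next compound is compound 3 `COc1ccc(-c2ssc(=O)c2-c2cc(OC)c(OC)c(OC)c2)cc1N`. It differs from compound 2 in one place, the 4-methoxyphenyl becoming 3-amino-4-methoxyphenyl: amino in place of hydrogen on an aromatic carbon. The new amino group stands ortho to a methoxy group and meta to a large group.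

Among the compounds with values here, no measured pair shows this change alone, so the size of the step cannot be read directly from the data. Within the data shown here, compound 1, at 3000 nM, is the only measured compound carrying an amino group, but it is not a clean comparison for compound 2. No firm direction is expected in this assay, and the expected step of a 1.2-fold lower number from compound 2 to compound 3 (0.06 log units; within the scatter) stays within the scatter, though the uncertainty is wide.

For compound 3 the estimated value is 400 nM, with an expected range of 90 nM to 1800 nM.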

Compound 3, half-maximal inhibitory concentration: 147 nM
Compound 3: the middle estimate sits 2.7-fold (0.43 log units) above what was measured, and the stated range covers the measured number.
By their numbers in this assay, from the lowest: compound 3; then compound 2; then compound 1.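

In this assay, within the data shown here, the change to 3-amino-4-methoxyphenyl gives the first direct reading at this position, a 3.2-fold lower number from compound 2 to compound 3 (0.50 log units; beyond the scatter), a modest step that lies beyond the scatter. Amino in place of hydrogen on this aromatic carbon, ortho to a methoxy group, is therefore tolerated here and goes with a lower number, something the high value of compound 1 alone gave no sign of. No supporting data on the origin of this step are available, so the result stands as an observation on the two compounds alone.

Going by these compounds, whether the step is specific to amino remains open: a hydroxyl, a methylamino or an acetamido group on the same carbon would show whether other groups give a similar number or whether the free amine matters. Also open is whether the same step holds with the thione of compound 1 in place of the carbonyl, since the partner of compound 1 without the amino group is not among the compounds shown here.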